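The compounds below may be only part of what the source reports. "The series", "measured", "known", "first", "only" and "open" are said of these compounds alone.

Compound 1 `O=C(/C(=C\c1ccc(Br)cc1)Sc1ccc(Br)cc1)c1ccc(Br)cc1`: 1000 nM
Compound 2 `O=C(/C(=C\c1ccc(Br)cc1)Sc1ccc(Br)cc1)c1ccc(Cl)cc1`: 1000 nM

Going by the values given here, compound 1 gives 1000 nM in a functional assay on DU-145 cells (Homo sapiens) for inhibition, read by trypan blue exclusion, with a stated time of 96 h (a lower number here means a stronger inhibitor of growth, a higher number a weaker inhibitor of growth), level with compound 2, its only measured neighbour. The next compound, compound 3 `O=C(/C(=C\c1ccc(Br)c([N+](=O)[O-])c1)Sc1ccc(Br)cc1)c1ccc(Br)cc1`, keeps the core of compound 1 and alters it in one place: nitro in place of hydrogen on an aromatic carbon. In other words, a nitro group takes the place of a hydrogen on an aromatic carbon.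

Among the compounds with values here, only one measured step is available as a guide, and it bears on this change only loosely: no change at the digits printed from compound 1 to compound 2 (within the scatter). That step swaps one halogen for another, whereas compound 3 gains a new group where compound 1 carries only hydrogen. Within the data shown here, no measured pair shows what adding a nitro group does in this assay, so the data point in neither direction. The best expectation is therefore no change beyond the scatter, with real uncertainty on both sides. The expected step is a 1.3-fold lower number from compound 1 to compound 3 (0.10 log units; within the scatter). Compound 3 is expected at 800 nM, within an estimated range of 200 nM to 3000 nM.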

Compound 3, concentration for 50% growth inhibition: 1000 nM
The estimate for compound 3 lay 1.3-fold (0.10 log units) below the measured number; low and high end bracket the measured number.
By their numbers in this assay, from the lowest: compounds 1, 2 and 3 (each within the scatter of the next).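

Putting a nitro group in place of a hydrogen gives no change at the digits printed from compound 1 to compound 3 (within the scatter) in this assay, so this carbon, ortho to a bromo group and meta to a large group, can carry a group of 3 heavy atoms without a shift beyond the scatter. The earlier pair showed only one halogen swapped for another elsewhere in the molecule, whereas this step adds a new group where compound 1 carries only hydrogen. Nothing available accounts for the flat result, so it stands here as an observation without an explanation.

Going by these compounds, whether an amine, a carboxylic acid or a methoxy group on this same carbon would also leave the number within the scatter remains open, so a single nitro group cannot show how freely this position accepts change. Also open, on these data alone, is whether the nitro group would have the same lack of effect in a compound without the bromo group to which it is ortho.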